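Working notes: from compound 2 to compound 4

This account rests on a few compounds, and the source may have more. Where it says the series, first, only, none or still open, it means among the compounds named here.

Measured in an ADME assay on CCRF-CEM cells (Homo sapiens) for cytotoxicity, with a stated time of 5 days; on this read-out lower numbers stand for stronger inhibition and higher numbers for weaker inhibition:
- compound 1 `COc1nc(NC2CC2)c2ncn([C@H]3C[C@H](N=[N+]=[N-])[C@@H](CO)O3)c2n1` gives > 100000 nM as a limit
- compound 2 `CC(C)(CO)Nc1nc(N)nc2c1ncn2[C@H]1C[C@H](N=[N+]=[N-])[C@@H](CO)O1` gives > 100000 nM as a limit
- compound 3 `COc1nc(F)nc2c1ncn2[C@H]1C[C@H](N=[N+]=[N-])[C@@H](CO)O1` gives > 100000 nM as a limit

Compound 2 gives > 100000 nM as a limit of the assay, not as a number. All three measured compounds share that limit (the limit of > 100000 nM in this assay, at which 3 of the 3 values shown sit). Compound 4 `CC(CO)Nc1nc(N)nc2c1ncn2[C@H]1C[C@H](N=[N+]=[N-])[C@@H](CO)O1` is still unmeasured. The change hydrogen in place of methyl on a saturated chain carbon bound to a nitrogen on an aromatic ring and two saturated chain carbons places hydrogen in place of methyl on a saturated chain carbon bound to a nitrogen on an aromatic ring and two saturated chain carbons. Among the compounds with values here, no measured pair shows a step of this kind. In this assay the step of a number no higher from compound 2 to compound 4 (the limit leaves the size open) is expected to stay within the scatter, in neither direction. This expectation rests on compound 2 at > 100000 nM, itself a limit. The estimated value for compound 4 is 100000 nM, with an expected range of 30000 nM to 200000 nM.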

Compound 4, half-maximal inhibitory concentration: > 100000 nM
Compound 4: no number, only a limit; the forecaster's own chance of this, stated with the estimate: 85%; the middle value lies on the limit itself.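

No step can be read from compound 2 to compound 4, because both values are limits: the limit of > 100000 nM in this assay, at which 4 of the 4 values shown sit.

The compounds shown leave open whether hydrogen in place of methyl at this place changes anything in this assay.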